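Swapping Hydrogen for tert-Butyl on the Benzyl Ring

A few compounds are considered here, and "the series" means these few. Any claim that something is new, unique, unknown or untested is made for them only; others in the source may bear on it.

Compound 2 `CC(=O)OC[C@H]1O[C@@H](n2cc(-c3cn(Cc4ccccc4)nn3)c(=O)[nH]c2=O)C[C@@H]1OC(C)=O` carries a plain benzyl group on the shared core. For the measured compounds named here, in a functional assay on NCI-H23 cells (Homo sapiens) for cytotoxicity, read by sulforhodamine B assay, tested at 10 uM (on this read-out higher numbers stand for more inhibition at the one concentration tested (going by the name of the read-out) and lower numbers for less inhibition), compound 2 gives 98.2%, the higher of the two numbers measured so far. Going by the values given here, its only measured neighbour is compound 1 `CC(=O)OC[C@H]1O[C@@H](n2cc(-c3cn(Cc4ccc(C(C)C)cc4)nn3)c(=O)[nH]c2=O)C[C@@H]1OC(C)=O`, which carries an isopropyl group on that ring and in this assay gives 86.7%. Among the compounds with values here, the one step measured, a number 11.5 percentage points higher from compound 1 to compound 2 (beyond the scatter), shows that taking the isopropyl away raised inhibition by a modest but real amount. Compound 3 `CC(=O)OC[C@H]1O[C@@H](n2cc(-c3cn(Cc4ccc(C(C)(C)C)cc4)nn3)c(=O)[nH]c2=O)C[C@@H]1OC(C)=O` goes the other way: tert-butyl in place of hydrogen on an aromatic carbon. Within the data shown here, this runs against the direction of the only step that bears on it, with a group of four carbons entering where the isopropyl sat before. Following that step, a modest fall in this assay is expected, a number 14.2 percentage points lower from compound 2 to compound 3 (beyond the scatter). For compound 3 the estimate is 84%, with a range from 66% to 97%.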

Compound 3, a percentage reported as inhibition, at one concentration (the size of the read-out at that concentration, not a potency): 106%
Compound 3: the middle estimate sits 22 percentage points below what was measured, and the stated range ends below it.
By their numbers in this assay, from the lowest: compound 1; then compounds 2 and 3 (each within the scatter of the next).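

Putting tert-butyl on this aromatic carbon, para to a large group, leaves no measurable loss in this assay: a number 7.8 percentage points higher from compound 2 to compound 3 (within the scatter). The lower number seen with isopropyl therefore does not carry over to every alkyl group at this place. The two substituted compounds also separate, a number 19.3 percentage points higher from compound 1 to compound 3 (beyond the scatter), so one extra methyl on the isopropyl group is enough to change the reading, and compound 1 stands against any simple trend with carbon count; nothing available here explains this difference.

Going by these compounds, it remains open whether an amine, a carboxylic acid or a longer chain at this place would keep the reading as high as in compound 3. On these data alone, with only one concentration tested, any difference in potency between compound 2 and compound 3 also remains open.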